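The source may report more compounds than this note shows. Statements on the series, on what has been measured and on what is new or still open speak of the compounds shown alone.

Two compounds of the series have numbers in an assay on isolated protein for binding affinity to Oxytocin receptor (Homo sapiens); on this read-out lower numbers stand for stronger inhibition and higher numbers for weaker inhibition. Compound 1 `CC(C)C[C@@H]1C(=O)N[C@H](C2Cc3ccccc3C2)C(=O)N1[C@@H](C(=O)NC(C)(C)C)c1ccoc1` gives 12.6 nM, and compound 2 `CNC(=O)c1ccc([C@H](C(=O)NC(C)C)N2C(=O)[C@@H](C3Cc4ccccc4C3)NC(=O)[C@H]2CC(C)C)o1` gives 39.8 nM; compound 2 thus stands at the higher of the two numbers, with compound 1 a gap beyond the scatter below it. Compound 3 `CC(C)C[C@@H]1C(=O)N[C@H](C2Cc3ccccc3C2)C(=O)N1[C@@H](C(=O)NC(C)C)c1cccs1` differs from compound 2 by a group of 5 heavy atoms (4 carbon, 1 sulfur; one five-membered aromatic ring with 1 hetero atom) in place of a group of 9 heavy atoms (6 carbon, 1 nitrogen, 2 oxygen; one five-membered aromatic ring with 1 hetero atom), on a saturated chain carbon bound to an amide-type nitrogen in a ring and a carbonyl carbon, the isopropyl amide being kept. Among the compounds with values here, no measured step of this kind exists. A modest move toward a lower number is expected because compound 1 with a five-membered aromatic ring with 1 hetero atom at this place gives 12.6 nM. The step from compound 2 to compound 3 is expected to be a 2.0-fold lower number from compound 2 to compound 3 (0.30 log units; within the scatter). Compound 3 is estimated at 20 nM, within 7 nM to 60 nM.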

Compound 3, inhibition constant: 6.31 nM
Estimate against measurement, compound 3: 3.2-fold (0.50 log units) above; measured number below the stated range.
By their numbers in this assay, from the lowest: compounds 3 and 1 (each within the scatter of the next); then compound 2.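

At the saturated chain carbon bound to an amide-type nitrogen in a ring and a carbonyl carbon, thiophen-2-yl in place of the group of 9 heavy atoms gives a 6.3-fold lower number from compound 2 to compound 3 (0.80 log units; beyond the scatter) in this assay, with the isopropyl amide held. Within the data shown here, this is the first step read at this place, and it shows that the larger group with its hydrogen-bond donor is not needed for the lower number. No measurement shown bears on the reason for this step.

The compounds shown leave open whether a phenyl ring, or a thiophen-2-yl carrying a carboxylic acid, would hold the number at this place. Going by these compounds, whether the step carries over to the tert-butyl amide also stays open.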